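Methoxyphenyl Variant of a Thiazolidinone in Paw Edema

A few compounds are considered here, and "the series" means these few. Any claim that something is new, unique, unknown or untested is made for them only; others in the source may bear on it.

Measured compounds:
Compound 1, `Cc1nc(-c2ccc(Cl)cc2)sc1C1SCC(=O)N1c1ccc(F)c(Cl)c1`, 65.1%
Compound 2, `Cc1nc(Cc2ccc(Cl)cc2)sc1C1SCC(=O)N1c1ccc(Cl)cc1`, 53.9%
Compound 3, `Cc1ccc(N2C(=O)CSC2c2sc(-c3ccc(Cl)cc3)nc2C)cc1`, 63.9%

In a functional assay on the whole organism (strain Wistar albino) for inhibition, with Rattus norvegicus as the target, read by paw edema, with stated times of 1 h and 4 h, at a dose of 40 mg/kg by the oral route (a lower number here means less inhibition, a higher number more inhibition at the dose given (going by the name of the read-out)), compound 1 stands highest of the three, though compound 3 lies within the scatter of it, while compound 2 sits lower by a margin beyond the scatter. The unmeasured compound 4, `COc1ccc(N2C(=O)CSC2c2sc(-c3ccc(Cl)cc3)nc2C)cc1`, differs from compound 1 in one place: 4-methoxyphenyl in place of 3-chloro-4-fluorophenyl on an amide-type nitrogen in a ring. Going by the values given here, the one measured step that bears on this swap is a number 1.2 percentage points lower from compound 1 to compound 3 (within the scatter), also a change of the ring on the amide-type nitrogen, which gave no shift beyond the scatter. Compound 4 is therefore expected to give a step of about a number 3.1 percentage points lower from compound 1 to compound 4 (within the scatter), that is none beyond the scatter. The estimate for compound 4 is 62%, within 50% to 74%.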

Compound 4, a percentage reported as inhibition, in the whole organism at one dose (the size of the read-out at that dose, not a potency): 59.1%
Compound 4: middle estimate off by 2.9 percentage points, on the high side, and the stated range covers the measured number.
By their numbers in this assay, from the lowest: compounds 2, 4, 3 and 1 (each within the scatter of the next, the first and the last beyond it).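

In this assay, 4-methoxyphenyl, which brings a hydrogen-bond acceptor to the amide-type nitrogen, gave a number 6 percentage points lower from compound 1 to compound 4 (within the scatter). Methoxy in place of methyl on an aromatic carbon gave a number 4.8 percentage points lower from compound 3 to compound 4 (within the scatter), so this position has now taken three different aromatic rings with no step beyond the scatter. Nothing available offers an explanation for these small steps. The compounds shown leave open whether an amine or a carboxylic acid in place of the methoxy group would also stay within the scatter.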